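The source may hold more compounds than are shown below. What is called first, only, known or untested is meant among the compounds shown, and "the series" means these compounds.

Of the compounds shown here, two with a shared core have been measured in a functional assay on HCT-116 cells (Homo sapiens) for cytotoxicity, read by MTT assay, with a stated time of 72 h; on this read-out lower numbers stand for stronger inhibition and higher numbers for weaker inhibition. Compound 1 `c1ccc(NN=C(c2nc3ccccc3[nH]2)c2nc3ccccc3[nH]2)cc1` carries a plain phenyl ring on its hydrazone arm; in this assay compound 1 gives 162000 nM. Compound 2 `Cc1ccc(NN=C(c2nc3ccccc3[nH]2)c2nc3ccccc3[nH]2)cc1` carries a methyl group on that ring; in this assay compound 2 gives 195000 nM. Going by the values given here, the only step between them, from compound 1 to compound 2, is a 1.2-fold higher number from compound 1 to compound 2 (0.08 log units; within the scatter), so the two numbers cannot be told apart, and compound 2 simply stands alongside compound 1 rather than beyond it.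

Compound 3 `COc1ccc(NN=C(c2nc3ccccc3[nH]2)c2nc3ccccc3[nH]2)cc1` now differs from compound 2 by methoxy in place of methyl on an aromatic carbon. Among the compounds with values here, the one step that bears on this place is the one from compound 1 to compound 2, which stayed within the scatter, and nothing else measured here speaks to a methoxy group at this position. With so little to go on, the expected outcome for compound 3 is no step beyond the scatter, a 1.1-fold lower number from compound 2 to compound 3 (0.02 log units; within the scatter). Compound 3 is therefore estimated at 185000 nM, with a range from 90000 nM to 380000 nM.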

Compound 3, half-maximal inhibitory concentration: 35700 nM
Compound 3: middle estimate off by 5.2-fold (0.71 log units), on the high side; the measured number lies below the stated range.
By their numbers in this assay, from the lowest: compound 3; then compounds 1 and 2 (each within the scatter of the next).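

On the aromatic carbon para to a large group, the change now produces a clear difference in this assay: methoxy in place of methyl gives a 5.5-fold lower number from compound 2 to compound 3 (0.74 log units; beyond the scatter) and methoxy in place of hydrogen gives a 4.5-fold lower number from compound 1 to compound 3 (0.66 log units; beyond the scatter). The earlier pair showed only that a methyl group at this carbon could not be told apart from hydrogen, so this position is not indifferent to every group placed on it, and among these three compounds only the methoxy compound stands apart from the others. Nothing available here explains why the number falls with methoxy.

On these data alone, it remains open whether the oxygen itself matters or whether other groups would do the same, and a hydroxyl group, an ethoxy group or an amine on this same carbon would help separate those possibilities. As far as these compounds go, compound 3 gives 35700 nM, and it is also open whether the number can fall further from there, and what a methoxy group would do on the other carbons of this ring.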